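The source may report more compounds than this note shows. Statements on the series, on what has been measured and on what is new or still open speak of the compounds shown alone.

Measured so far:
Compound 1, `C/N=C(\S)NCCCn1nc(-c2ccccc2)ccc1=O`: > 100 mg/kg
Compound 2, `CN/C(=N/CCCCn1nc(-c2ccc(OC)cc2)ccc1=O)NC#N`: > 100 mg/kg

Both compounds were tested in a functional assay on the whole organism (stomach) with Rattus norvegicus as the target; on this read-out lower numbers stand for an effect already at smaller amounts and higher numbers for an effect only at larger amounts of compound. For compound 1 the value > 100 mg/kg is not a number but a limit of the assay, meaning no half-maximal effect was reached at the highest dose given. The same holds for compound 2, whose value > 100 mg/kg is also such a limit. So compound 1 stands at the limit of > 100 mg/kg in this assay, at which 2 of the 2 values shown sit, and no compound on record gives a number that could anchor it.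

The next compound to look at is compound 3, `N#CNC(=N)NCCCCCn1nc(-c2ccccc2)ccc1=O`. Relative to compound 1 the change is a group of 8 heavy atoms (4 carbon, 4 nitrogen; no ring) in place of a group of 5 heavy atoms (2 carbon, 2 nitrogen, 1 sulfur; no ring), on a saturated chain carbon, three bonds along the chain from an aromatic nitrogen. Within the data shown here, no measured step matches this exchange, so its effect on this assay can only be guessed.

Since the two values at hand are both limits, the expectation for compound 3 is that it most likely stays at a limit as well, and the step that the limit leaves unreadable from compound 1 to compound 3 is expected to be none beyond the scatter. Compound 3 is estimated at 150 mg/kg, with a range from 40 mg/kg to 600 mg/kg.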

Compound 3, dose for half-maximal effect: > 100 mg/kg
Compound 3 gave a limit, no number; the forecaster's own chance of this, stated with the estimate: 70%; the middle value is on the limit's open side.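

Compound 3 gives > 100 mg/kg, which is a limit and not a number. Among these compounds, with compound 1 at a limit as well, no step from compound 1 to compound 3 can be read in this assay, and the values shown all sit together: the limit of > 100 mg/kg in this assay, at which 3 of the 3 values shown sit. What stays open is the dose at which any of these compounds reaches a half-maximal effect, and whether the exchange of groups alters it.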